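Aryl Swap on a Shared Quinoline Urea Core

The source may hold more compounds than are shown below. What is called first, only, known or untested is meant among the compounds shown, and "the series" means these compounds.

Three measured compounds share one core and were tested in a functional assay on SW-620 cells (Homo sapiens) for inhibition, read by MTT assay, with a stated time of 72 h; a higher number here means a weaker inhibitor, a lower number a stronger inhibitor. Compound 3 `COc1cc(NC(C)CCCNC(=O)NNC(=O)Nc2cccc(C(F)(F)F)c2)c2ncccc2c1` gives 21000 nM in this assay. Compound 1 `COc1cc(NC(C)CCCNC(=O)NNC(=O)Nc2ccc(Cl)cc2)c2ncccc2c1` carries the change (4-chlorophenyl in place of 3-(trifluoromethyl)phenyl on an amide-type nitrogen), and in this assay compound 1 gives 48000 nM, a step of a 2.3-fold higher number from compound 3 to compound 1 (0.36 log units; beyond the scatter). Compound 2 `COc1cc(NC(C)CCCNC(=O)Nc2cccc(C(F)(F)F)c2)c2ncccc2c1` differs from compound 3 in a way that is not broken down here; in this assay compound 2 gives 22000 nM, and the step of a 2.2-fold lower number from compound 1 to compound 2 (0.34 log units; beyond the scatter) lies beyond the scatter. Compound 4 `COc1cc(NC(C)CCCNC(=O)Nc2ccc(Cl)cc2)c2ncccc2c1` has not yet been measured; it carries the same change, (4-chlorophenyl in place of 3-(trifluoromethyl)phenyl on an amide-type nitrogen), at the same place. That change occurs twice among these compounds. Resting on a 2.3-fold higher number from compound 3 to compound 1 (0.36 log units; beyond the scatter), the step from compound 2 to compound 4 in this assay is expected to be a 2.2-fold higher number from compound 2 to compound 4 (0.34 log units; beyond the scatter). Compound 4 is therefore estimated at 48000 nM, with a likely range from 20000 nM to 115000 nM.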

Compound 4, half-maximal inhibitory concentration: 28000 nM
Beside the measured number, compound 4's estimate is 1.7-fold (0.23 log units) above it; the measured number falls inside the stated range.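

In this assay, 4-chlorophenyl in place of 3-(trifluoromethyl)phenyl gave a 1.3-fold higher number from compound 2 to compound 4 (0.10 log units; within the scatter), while 4-chlorophenyl in place of ((4-chlorophenyl)carbamoyl)amino gave a 1.7-fold lower number from compound 1 to compound 4 (0.23 log units; within the scatter). The same aryl change on the two cores can't be told apart in size: the same change on two cores in this assay, a 2.3-fold higher number (0.36 log units; beyond the scatter) from compound 3 to compound 1 and a 1.3-fold higher number (0.10 log units; within the scatter) from compound 2 to compound 4, 1.8-fold (0.25 log units) apart, within the scatter of two such steps This agreement shows that the change carried between these two cores without a detectable difference, but it rests on a single pair per core and doesn't establish a fixed step for any other core.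

The compounds shown leave open what a carboxylic acid or an amine in place of either aryl group would do. They also leave open the effect of a longer chain on the amide-type nitrogen.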